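The source may hold more compounds than are shown below. What is called first, only, known or untested is meant among the compounds shown, and "the series" means these compounds.

Compounds measured in a physicochemical assay for lipophilicity; on this read-out higher numbers stand for higher lipophilicity and lower numbers for lower lipophilicity:
compound 1 `CC(/C=C/CC(C)CCCC(C)C)=C\C(=O)OC(C)(C)C` — 7.56
compound 2 `COC(C)(C)CCCC(C)C/C=C/C(C)=C/C(=O)OC(C)(C)C` — 6.36
compound 3 `CC(=O)OC(C)(C)CCCC(C)C/C=C/C(C)=C/C(=O)OC(C)C` — 5.98

Compound 1 stands highest of the three numbers in this assay; compound 2 is nearest to it, compound 3 furthest, and both gaps lie beyond the scatter. Within the data shown here, the only single-place step among the measured compounds is a number 1.20 log units lower from compound 1 to compound 2 (beyond the scatter), a large drop for a change on the saturated chain. Compound 3 carries two changes relative to compound 2 and its value sits a little under that of compound 2.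

Compound 4 `CCNC(=O)/C=C(C)/C=C/CC(C)CCCC(C)C` is not yet measured. It differs from compound 1 as follows: ethylamino in place of tert-butoxy on a carbonyl carbon. Among the measured compounds shown here, no measured step concerns the ester end of the chain, so the step from compound 1 to compound 2 only shows that one change on this core can move this assay by more than a unit. With a larger group leaving than entering, and a hydrogen-bond donor entering in place of an acceptor, a drop in this assay beyond the scatter is expected, estimated as a number 2.06 log units lower from compound 1 to compound 4 (beyond the scatter). For compound 4 the expected value is 5.5, with a range from 4.8 to 6.2.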

Compound 4, partition coefficient: 5.24
Estimate against measurement, compound 4: 0.26 log units above; the measured number falls inside the stated range.
By their numbers in this assay, from the lowest: compound 4; then compound 3; then compound 2; then compound 1.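

In this assay, ethylamino in place of tert-butoxy on a carbonyl carbon gives a number 2.32 log units lower from compound 1 to compound 4 (beyond the scatter), so this position responds strongly to a single change. With a number 1.20 log units lower from compound 1 to compound 2 (beyond the scatter), from a change on a saturated chain carbon, two separate places on the core of compound 1 now each lower the number beyond the scatter. The change alters group size and hydrogen-bond donor and acceptor counts together, and no available data separate these contributions or account for the drop.

Open, on these data alone, is whether a dimethylamino group on the same carbonyl carbon, which carries no amide hydrogen, would give a similar step, and where a carboxylic acid there would fall. Also open, as far as these compounds go, is whether the ethylamino and methoxy steps would add up when combined in one compound.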